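A few compounds are considered here, and "the series" means these few. Any claim that something is new, unique, unknown or untested is made for them only; others in the source may bear on it.

Of the compounds shown here, three have so far been tested in a functional assay on C6 cells (Rattus norvegicus) for cytotoxicity, read by MTT assay, with a stated time of 24 h, tested at 50 ug/mL; a lower number here means a stronger effect, a higher number a weaker effect of the compound at the concentration tested. Compound 1 `Cc1nnc(SCC(=O)N/N=c2/scc(-c3ccccc3)n2-c2ccccc2)s1` gives 63.9%, compound 2 `Cc1ccc(-c2cs/c(=N/NC(=O)CSc3nncn3C)n2-c2ccccc2)cc1` gives 53.8%, and compound 3 `Cn1cnnc1SCC(=O)N/N=c1/scc(-c2ccc(C#N)cc2)n1-c1ccccc1` gives 58.8%. Compound 3 thus stands second highest of the three numbers, within the scatter of both compound 2 and compound 1. Within the data shown here, the only single-point step among them, a number 5 percentage points higher from compound 2 to compound 3 (within the scatter), changed the same aromatic carbon that is now altered again. Compound 4 `Cn1cnnc1SCC(=O)N/N=c1/scc(-c2ccccc2)n1-c1ccccc1` differs from compound 3 as follows: hydrogen in place of cyano on an aromatic carbon. Since that one measured step stayed within the scatter, a step of similar smallness is expected here, a number 0.8 percentage points lower from compound 3 to compound 4 (within the scatter), with no clear direction. Compound 4 is therefore estimated to give 58% in this assay, between 45% and 72%.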

Compound 4, a percentage reported as activity, at one concentration (the size of the read-out at that concentration, not a potency): 62.4%
Beside the measured number, compound 4's estimate is 4.4 percentage points below it; measured number inside the range.
By their numbers in this assay, from the lowest: compounds 2, 3, 4 and 1 (each within the scatter of the next, the first and the last beyond it).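

Among these compounds, at this aromatic carbon, hydrogen, cyano and methyl are not told apart in this assay: the steps of a number 3.6 percentage points higher from compound 3 to compound 4 (within the scatter) and a number 8.6 percentage points higher from compound 2 to compound 4 (within the scatter) both stay small, even though cyano and methyl had so far been compared only with each other. On the sulfur, 4-methyl-4H-1,2,4-triazol-3-yl in place of 5-methyl-1,3,4-thiadiazol-2-yl also gives only a number 1.5 percentage points lower from compound 1 to compound 4 (within the scatter) and so separates nothing at that second place. No measurement at hand offers an explanation for these numbers. As far as these compounds go, whether an amine or a carboxylic acid on this aromatic carbon would carry the number beyond the scatter stays open.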